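The source may report more compounds than this note shows. Statements on the series, on what has been measured and on what is new or still open speak of the compounds shown alone.

In a functional assay on SK-OV-3 cells (Homo sapiens) for cytotoxicity, read by MTT assay, with a stated time of 3 days (a higher number here means a weaker inhibitor, a lower number a stronger inhibitor), compound 1 (`CCNc1nc(SCc2nc3ccccc3[nH]2)nc(-c2ccccc2)c1C#N`) gives 7.35 nM, compound 2 (`N#Cc1c(Nc2ccccn2)nc(SCc2nc3ccccc3[nH]2)nc1-c1ccccc1`) gives 5.81 nM and compound 3 (`N#Cc1c(NC(N)=O)nc(SCc2nc3ccccc3[nH]2)nc1-c1ccccc1`) gives 6.75 nM, so compound 1 stands level with both within the scatter. Compound 4 (`CN1CCN(c2nc(SCc3nc4ccccc4[nH]3)nc(-c3ccccc3)c2C#N)CC1`) keeps the shared core and alters the same place: 4-methylpiperazin-1-yl in place of ethylamino on an aromatic carbon. Two measured swaps at this place bear on it: a 1.3-fold lower number from compound 1 to compound 2 (0.10 log units; within the scatter) and a 1.1-fold lower number from compound 1 to compound 3 (0.04 log units; within the scatter). Neither moved the number in this assay beyond the scatter. Going by the values given here, no measured compound carries a six-membered non-aromatic ring here, so this change is untested and the range stays wide. The expected step is small, no more than the scatter: a 1.1-fold lower number from compound 1 to compound 4 (0.02 log units; within the scatter). The estimate for compound 4 is 7 nM, with an expected range from 3 nM to 18 nM.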

Compound 4, half-maximal inhibitory concentration: 1600 nM
Compound 4: the middle estimate sits 230-fold (2.36 log units) below what was measured; the measured number lies above the stated range.
By their numbers in this assay, from the lowest: compounds 2, 3 and 1 (each within the scatter of the next); then compound 4.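

In this assay, this position proved far from indifferent. The swaps among ethylamino, ureido and (pyridin-2-yl)amino stayed within the scatter, whereas 4-methylpiperazin-1-yl gives a 220-fold higher number from compound 1 to compound 4 (2.34 log units; beyond the scatter), along with a 240-fold higher number from compound 3 to compound 4 (2.37 log units; beyond the scatter) and a 280-fold higher number from compound 2 to compound 4 (2.44 log units; beyond the scatter). So the earlier tolerance at this aromatic carbon does not extend to this group, which brings a six-membered non-aromatic ring and 0 hydrogen-bond donors.

The compounds shown leave open whether the ring, its methyl or the missing donor goes with this large step; piperazin-1-yl, morpholin-4-yl or dimethylamino at this carbon would help separate them. Nothing measured here explains the step.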